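A Chloro Group on a Cytotoxically Silent Anilino Compound

A few compounds are considered here, and "the series" means these few. Any claim that something is new, unique, unknown or untested is made for them only; others in the source may bear on it.

Compound 1 `N#Cc1c(F)c(F)c2nc(N)nc(N)c2c1F` and compound 2 `N#Cc1c(Nc2ccccc2)c(F)c2nc(N)nc(N)c2c1F` share one core. In a functional assay on A549 cells (Homo sapiens) for cytotoxicity, read by MTT assay (a lower number here means a stronger inhibitor, a higher number a weaker inhibitor), compound 1 gives > 1000 ug/mL, which is a limit of the assay rather than a number. In this assay compound 2 gives > 1000 ug/mL, likewise a limit. The change between the two, anilino in place of fluoro on an aromatic carbon, is a step that the two limits leave unreadable from compound 1 to compound 2. Compound 2 therefore stands at the limit of > 1000 ug/mL in this assay, at which 2 of the 2 values shown sit, with no measured number of its own.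

Compound 3 `N#Cc1c(Nc2ccc(Cl)cc2)c(F)c2nc(N)nc(N)c2c1F` differs from compound 2 by chloro in place of hydrogen on an aromatic carbon. Within the data shown here, the only measured step, a step that the two limits leave unreadable from compound 1 to compound 2, concerns a different change and cannot be sized, so it offers no direction for the chloro change. Among the measured compounds shown here, nothing among the measured values points to a step beyond the scatter in this assay for compound 3, and the expected outcome for compound 3 is another limit, corresponding to an estimated step of a number no higher from compound 2 to compound 3 (the limit leaves the size open). Compound 3 is expected to give about 1000 ug/mL, within an estimated range from 400 ug/mL to 3000 ug/mL.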

Compound 3, half-maximal inhibitory concentration: 115 ug/mL
For compound 3 the middle estimate is 8.7-fold (0.94 log units) above the measured one; measured number outside the range, below it.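

In this assay, chloro in place of hydrogen, on an aromatic carbon para to a large group, gives an at least 8.6-fold lower number from compound 2 to compound 3 (0.93 log units; beyond the scatter), the first sign that this outer ring can carry cytotoxic effect in the series. Replacing fluoro with (4-chlorophenyl)amino at the same place on the shared core gives an at least 8.6-fold lower number from compound 1 to compound 3 (0.93 log units; beyond the scatter), whereas the step with plain anilino at that place cannot be read, so a measurable effect at this position appears here only with the chloro group present. Both steps are minimum sizes, and the real distance from compound 2 stays unknown, because compound 2 has only a limit and no number of its own: the limit of > 1000 ug/mL in this assay, at which 2 of the 3 values shown sit.

The compounds shown leave open whether chlorine is specifically needed at this place, or whether another group there, such as a methoxy, an amine or a carboxylic acid, would also bring a measurable value. They also give no measured property that would explain the step, so its cause remains unresolved.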